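From pyridin-2-yl to 2-carboxyethyl on the shared core

The source may hold more compounds than are shown below. What is called first, only, known or untested is meant among the compounds shown, and "the series" means these compounds.

In an ADME assay on S9 fraction from liver (Rattus norvegicus) for metabolic stability, read by LC-MS, using NADPH, with a stated time of 30 min (on this read-out higher numbers stand for a more stable compound and lower numbers for a less stable compound), compound 1 `CCCCCCCCc1ccc(OCC(=O)Cn2nnc(C)n2)cc1` reads < 5% as a limit and not a number. Among the measured compounds shown here, compound 2 `CCCCCCCCc1ccc(OCC(=O)Cn2nnc(-c3ccccn3)n2)cc1` gives 30% as the only true number so far. For the measured compounds named here, its one measured step is a number at least 25 percentage points higher from compound 1 to compound 2 (beyond the scatter) and came with pyridin-2-yl in place of methyl. Compound 3 `CCCCCCCCc1ccc(OCC(=O)Cn2nnc(CCC(=O)O)n2)cc1` has 2-carboxyethyl in place of pyridin-2-yl on an aromatic carbon on an aromatic carbon. Going by the values given here, only that step bears on this change, so part of its gain may be lost as pyridin-2-yl leaves. The expected change is a number 12 percentage points lower from compound 2 to compound 3 (beyond the scatter) by estimate, a modest fall. For compound 3 the estimate is 18% with an expected range from 5% to 40% in this reading.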

Compound 3, percent of the compound remaining: < 5%
Compound 3 gave a limit, no number; the forecaster's own chance of this, stated with the estimate: 20%; middle value at least 13 percentage points from the limit.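

With 2-carboxyethyl in place of pyridin-2-yl on this aromatic carbon, this assay shows a number at least 25 percentage points lower from compound 2 to compound 3 (beyond the scatter). The higher reading of compound 2 therefore does not extend to every larger group at this position: of the three groups shown, only pyridin-2-yl gives a true number. The pair of compound 1 and compound 3 cannot be read, because both values are limits: the limit of < 5% in this assay, at which 2 of the 3 values shown sit.

Going by these compounds, what stays open is whether an aromatic ring alone is enough here, or whether its ring nitrogen also matters. A phenyl group at this position would separate these two possibilities.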